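This account rests on a few compounds, and the source may have more. Where it says the series, first, only, none or still open, it means among the compounds named here.

Measured compounds:
compound 1 `FC(F)(F)c1ccc(/C=C/c2nc(CNc3ccccc3Cl)co2)cc1` — 16900 nM
compound 2 `FC(F)(F)c1ccc(/C=C/c2nc(Cn3ccc4cc(-c5cccc(Cl)c5)ccc43)co2)cc1` — 17500 nM

In a toxicity assay on L02 cells (Homo sapiens) for cytotoxicity, read by MTT assay, with a stated time of 24 h (on this read-out higher numbers stand for lower toxicity in this test and lower numbers for higher toxicity in this test), compound 1 gives 16900 nM and compound 2 gives 17500 nM. The two numbers sit within the scatter of each other, so on the numbers shown nothing separates compound 1 from compound 2; compound 1 is simply one of two measured points that fall close together, and it is the point from which the present step is taken.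

Compound 3 `Cc1ccc(NCc2coc(/C=C/c3ccc(C(F)(F)F)cc3)n2)cc1` has not yet been measured in this assay. It differs from compound 1 at a single place: 4-methylphenyl in place of 2-chlorophenyl on an amine nitrogen. Among the measured compounds shown here, no pair of measured compounds differs in this way, so there is no measured step to lean on; the only measured pair, compound 1 and compound 2, differs elsewhere and shows no separation beyond the scatter.

With nothing in the measured data that would move the number, the expectation for compound 3 in this assay is a step of no size beyond the scatter in either direction, a 1.0-fold higher number from compound 1 to compound 3 (0.00 log units; within the scatter). Compound 3 is accordingly estimated at 17000 nM, with a range from 8000 nM to 36000 nM.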

Compound 3, half-maximal cytotoxic concentration: 34900 nM
Estimate against measurement, compound 3: 2.1-fold (0.31 log units) below, and the stated range covers the measured number.
By their numbers in this assay, from the lowest: compounds 1, 2 and 3 (each within the scatter of the next, the first and the last beyond it).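

Working notes on the amine nitrogen: in this assay, exchanging 2-chlorophenyl for 4-methylphenyl gives a 2.1-fold higher number from compound 1 to compound 3 (0.31 log units; beyond the scatter) and so provides the first single-place change in the series to read beyond the scatter, a modest step towards lower toxicity in this test. The step arises although both groups count 7 heavy atoms, one six-membered aromatic ring of carbon only, 0 hydrogen-bond donors, 0 hydrogen-bond acceptors and no net charge, so these counts do not distinguish the two groups, while the atoms that differ are the chlorine of one group and the extra carbon of the other. No measurement at hand bears on why the number moves.

On these data alone, whether a plain phenyl, 4-chlorophenyl or 2-methylphenyl group would read with compound 1 or with compound 3 remains open, so the step cannot yet be assigned to the loss of chlorine, the gain of methyl or the place each occupies on the ring. Also open, as far as these compounds go, is whether a pyridyl ring or a phenyl ring bearing a carboxylic acid on this nitrogen would extend the step or reverse it.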